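This account rests on a few compounds, and the source may have more. Where it says the series, first, only, none or still open, it means among the compounds named here.

In an ADME assay (liver) for metabolic stability, with Liver microsome (Homo sapiens) as the target, read by LC-MS, using microsomes, with a stated time of 1 h, tested at 5 uM (a lower number here means that less of the compound is left, a higher number that more of the compound is left), compound 3 (`Cc1nc(-c2ccccc2)c(C(=O)N2CCN(c3cc(Cl)cc(Cl)c3)CC2)o1`) gives 66.3% and lies within the scatter of compound 2 (`Cc1nc(-c2ccc(F)cc2)c(C(=O)N2CCN(c3cc(Cl)cc(Cl)c3)CC2)o1`), which gives 71.8% in the same measurement. Compound 1 (`Cc1nc(-c2ccccc2F)c(C(=O)N2CCN(c3cc(Cl)cc(Cl)c3)CC2)o1`) at 82.3% stands apart from both, beyond the scatter. Compound 4 (`Cc1nc(-c2cccc(F)c2)c(C(=O)N2CCN(c3cc(Cl)cc(Cl)c3)CC2)o1`) differs from compound 3 by the change from phenyl to 3-fluorophenyl, fluoro in place of hydrogen on an aromatic carbon. Two measured steps make the reverse exchange, hydrogen in place of fluoro: a number 16 percentage points lower from compound 1 to compound 3 (beyond the scatter) is modest and beyond the scatter, while a number 5.5 percentage points lower from compound 2 to compound 3 (within the scatter) stays within it. Going by the values given here, the step of a number 10.5 percentage points lower from compound 1 to compound 2 (beyond the scatter) also lies beyond the scatter, so the two fluoro compounds do not read alike, and no measured compound carries 3-fluorophenyl. Taken in reverse, the two exchange steps both point upward, one of them only within the scatter, so a small rise is expected here. The expected step is a number 5.7 percentage points higher from compound 3 to compound 4 (within the scatter) and it is expected to remain within the scatter. For compound 4 the estimate in this assay is 72% with an expected range from 61% to 83% as the likely span.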

Compound 4, percent of the compound remaining: 75.9%
The estimate for compound 4 lay 3.9 percentage points below the measured number, and the stated range covers the measured number.
By their numbers in this assay, from the lowest: compounds 3, 2, 4 and 1 (each within the scatter of the next, the first and the last beyond it).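

With 3-fluorophenyl in place of phenyl, this assay gives a number 9.6 percentage points higher from compound 3 to compound 4 (within the scatter), so fluoro on this carbon joins fluoro on the 4-position of the phenyl ring in leaving the read-out within the scatter of the unsubstituted compound, and only the 2-fluorophenyl of compound 1 remains beyond the scatter of compound 3. The new compound also closes the gap between the two earlier fluoro compounds: the exchange of 4-fluorophenyl for 3-fluorophenyl gives a number 4.1 percentage points higher from compound 2 to compound 4 (within the scatter) and the exchange of 2-fluorophenyl for 3-fluorophenyl gives a number 6.4 percentage points lower from compound 1 to compound 4 (within the scatter), so 3-fluorophenyl cannot be told apart from either, although those two stand beyond the scatter of each other. No supporting evidence bears on why these fluoro isomers read as they do.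

The compounds shown leave open how a larger or differently built group on this carbon, such as methoxy, trifluoromethyl or an amine, would read in this measurement. They also leave open whether two fluoro atoms on the same phenyl ring would read like 2-fluorophenyl, like 3-fluorophenyl or like neither.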